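The compounds below may be only part of what the source reports. "The series", "measured", "known", "first", "only" and "open" are said of these compounds alone.

Compound 1 `CC(C)Nc1nccc(-c2cn[nH]c2)n1`: 0.021 mL/min/kg
Compound 2 `OC1CCCC(c2n[nH]cc2-c2ccnc(NC3CCCC3)n2)C1`: 0.015 mL/min/kg

Both numbers come from an in vitro ADME assay on microsomes from liver (Homo sapiens) for metabolic stability; a higher number here means faster removal of the compound, a lower number slower removal. Compound 2 gives 0.015 mL/min/kg, and compound 1 gives 0.021 mL/min/kg. These two values lie within the usual scatter of each other, so compound 2 cannot be told apart from compound 1 here, and both numbers are small.

Compound 3 `c1cc(-c2c[nH]nc2C2CCCOC2)nc(NC2CCCC2)n1` has not yet been measured. It carries oxan-3-yl in place of 3-hydroxycyclohexyl on an aromatic carbon. Going by the values given here, no measured pair shows what a change of this kind does, so any expectation here is tentative and rests only on the two values in hand. The expected step of a 1.3-fold higher number from compound 2 to compound 3 (0.12 log units; within the scatter) stays within the scatter, with no firm direction. The estimated value for compound 3 is 0.02 mL/min/kg, with an expected range of 0.009 mL/min/kg to 0.045 mL/min/kg.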

Compound 3, clearance: 0.089 mL/min/kg
Compound 3: middle estimate off by 4.5-fold (0.65 log units), on the low side; measured number outside the range, above it.
By their numbers in this assay, from the lowest: compounds 2 and 1 (each within the scatter of the next); then compound 3.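

Putting oxan-3-yl in place of 3-hydroxycyclohexyl on this aromatic carbon of the five-membered ring gives, in this assay, a 5.9-fold higher number from compound 2 to compound 3 (0.77 log units; beyond the scatter), so the group at this position can matter for this read-out. The swap looks small on paper: both groups are six-membered non-aromatic rings containing one oxygen, but the entering group has no hydrogen-bond donor and has its oxygen inside the ring. Nothing measured here explains why the number rises.

This single pair changes the donor count and the place of the oxygen together, so it cannot show which of the two goes with the step. Going by these compounds, a plain cyclohexyl group, or a cyclohexyl ring carrying an amine instead of the hydroxyl, would be needed to separate these features, and how either behaves at this position remains open.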